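Adding a Third Methoxy Group: An Expected Small Step

This account rests on a few compounds, and the source may have more. Where it says the series, first, only, none or still open, it means among the compounds named here.

Compound 1 `COc1cc(-c2cc(C(=O)/C=C/c3ccc(Cl)cc3)nc3cc(-c4ccccc4)nn23)cc(OC)c1OC` gives 21600 nM in a functional assay on MDA-MB-231 cells (Homo sapiens) for antiproliferative activity, read by MTT assay, with a stated time of 24 h; on this read-out higher numbers stand for weaker inhibition and lower numbers for stronger inhibition.
Compound 2 `COc1cc(-c2cc(C(=O)/C=C/c3ccccc3)nc3cc(-c4ccccc4)nn23)cc(OC)c1OC` gives 19200 nM in this assay.
Compound 3 `COc1ccc(-c2cc(C(=O)/C=C/c3cc(OC)c(OC)c(OC)c3)nc3cc(-c4ccccc4)nn23)cc1OC` gives 16700 nM in this assay.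

These three numbers sit close together. Compound 3 differs from compound 2 and from compound 1 by less than the usual scatter, so none of the three can be called stronger or weaker than another. For the measured compounds named here, the single measured step that changes one point, a 1.1-fold lower number from compound 1 to compound 2 (0.05 log units; within the scatter), also stays within the scatter.

Compound 4 `COc1cc(/C=C/C(=O)c2cc(-c3cc(OC)c(OC)c(OC)c3)n3nc(-c4ccccc4)cc3n2)cc(OC)c1OC` has not been measured. Compared with compound 3 it carries methoxy in place of hydrogen on an aromatic carbon. Going by the values given here, no measured step tests this particular change, and the one step that is known was flat, so no movement beyond the scatter is expected in this assay. Compound 4 is therefore estimated at 14000 nM, within 6000 nM to 35000 nM, an expected step of a 1.2-fold lower number from compound 3 to compound 4 (0.08 log units; within the scatter).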

Compound 4, half-maximal inhibitory concentration: 18400 nM
The estimate for compound 4 lay 1.3-fold (0.12 log units) below the measured number; low and high end bracket the measured number.
By their numbers in this assay, from the lowest: compounds 3, 4, 2 and 1 (each within the scatter of the next).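

In this assay, the change from 3,4-dimethoxyphenyl to 3,4,5-trimethoxyphenyl gives a step within the scatter (a 1.1-fold higher number from compound 3 to compound 4 (0.04 log units; within the scatter)), so this added methoxy, the first one tested at this place, leaves the number effectively where it was. Compound 4 also shows that the group on the double-bonded chain carbon can be 3,4,5-trimethoxyphenyl without a step beyond the scatter, whether it replaces phenyl (a 1.0-fold lower number from compound 2 to compound 4 (0.02 log units; within the scatter)) or 4-chlorophenyl (a 1.2-fold lower number from compound 1 to compound 4 (0.07 log units; within the scatter)). No measurement offers an explanation for these flat steps. On these data alone, whether an amine, a carboxylic acid or a longer chain at this ring position would move the number beyond the scatter remains open.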